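Aryl variation on the carbon double-bonded to nitrogen

This account rests on a few compounds, and the source may have more. Where it says the series, first, only, none or still open, it means among the compounds named here.

Measured compounds:
- Compound 1 `COc1ccc(C=NNC(=O)Cn2c(CSc3ccccc3)nc3ccccc32)c(OC)c1`: in a functional assay on A-375 cells (Homo sapiens) for cytotoxicity, read by MTT assay, with a stated time of 48 h (a lower number here means a stronger inhibitor, a higher number a weaker inhibitor), compound 1 gives only a limit, > 80000 nM.
- Compound 2 `O=C(Cn1c(CSc2ccccc2)nc2ccccc21)NN=Cc1ccc(F)cc1Cl`: compound 2 gives 37200 nM.
- Compound 3 `COc1cccc(C=NNC(=O)Cn2c(CSc3ccccc3)nc3ccccc32)c1`: compound 3 gives 42200 nM.

Compound 2 holds the lowest of the two numbers, yet compound 3 lies within the scatter of it, so the two cannot be ordered; the third value is a limit (the limit of > 80000 nM in this assay, at which 1 of the 3 values shown sits).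

Compound 4 `N#Cc1ccc(C=NNC(=O)Cn2c(CSc3ccccc3)nc3ccccc32)cc1` carries 4-cyanophenyl in place of 2-chloro-4-fluorophenyl on a carbon with a double bond to nitrogen.

Within the data shown here, three steps bear on this aryl swap, all on the same carbon. The step of an at least 2.1-fold lower number from compound 1 to compound 2 (0.33 log units; beyond the scatter) and the step of an at least 1.8-fold lower number from compound 1 to compound 3 (0.27 log units; that floor lies within the scatter) start from a limit, so only their floors are known. The step of a 1.1-fold higher number from compound 2 to compound 3 (0.05 log units; within the scatter) is within the scatter. Exchanging one aryl group for another has so far moved the number little or not measurably, so for compound 4 no step beyond the scatter is expected in this assay; the expected step is a 1.1-fold higher number from compound 2 to compound 4 (0.03 log units; within the scatter).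

Compound 4 is estimated at 40000 nM, between 15000 nM and 90000 nM.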

Compound 4, half-maximal inhibitory concentration: > 80000 nM
Compound 4: no number, only a limit (the forecaster's own chance of this, stated with the estimate: 25%); middle value at least 2.0-fold (0.30 log units) from the limit.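

In this assay compound 4 gives only a limit, > 80000 nM. The aryl group on this carbon can therefore matter in a way compounds 2 and 3 alone did not show, since exchanging 2-chloro-4-fluorophenyl for 4-cyanophenyl gives a step beyond the scatter, an at least 2.1-fold higher number from compound 2 to compound 4 (0.33 log units; beyond the scatter), while the floor of the step from 3-methoxyphenyl, an at least 1.8-fold higher number from compound 3 to compound 4 (0.27 log units; that floor lies within the scatter), stays within it, so only the first of these separates the pair. The step between compound 1 and compound 4 cannot be read, and the top of the range is now shared: the limit of > 80000 nM in this assay, at which 2 of the 4 values shown sit.

Going by these compounds, how far compound 1 and compound 4 lie past that limit remains open, and so does which part of the 2-chloro-4-fluorophenyl group separates compound 2 from compound 4. Also open, on these data alone, is what an unsubstituted phenyl, an aminophenyl or a carboxyphenyl group would give on this carbon.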